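Removing the Ethoxycarbonyl Group from Compound 2

The source may report more compounds than this note shows. Statements on the series, on what has been measured and on what is new or still open speak of the compounds shown alone.

Measured in an ADME assay on WI-38 cells (Homo sapiens) for inhibition, read by MTT assay, with a stated time of 72 h; a lower number here means a stronger inhibitor, a higher number a weaker inhibitor:
Compound 1, `O=C(OC1(C(=O)Nc2ccc([N+](=O)[O-])cc2)CCCCC1)c1ccc(C(F)(F)F)cc1`: 185 nM
Compound 2, `CCOC(=O)c1ccccc1C(=O)OC1(C(=O)Nc2ccc([N+](=O)[O-])cc2)CCCCC1`: 386 nM

Compound 2 holds the highest of the two numbers; its nearest neighbour is compound 1, whose number is lower by a gap beyond the usual scatter. Compound 3, `O=C(OC1(C(=O)Nc2ccc([N+](=O)[O-])cc2)CCCCC1)c1ccccc1`, differs from compound 2 by hydrogen in place of ethoxycarbonyl on an aromatic carbon. Going by the values given here, no measured pair isolates this change, so the expectation rests on compound 1 and compound 2 alone. In this assay the expected step is a 1.5-fold lower number from compound 2 to compound 3 (0.17 log units; within the scatter), a modest move toward a lower number, at the edge of the scatter. Compound 3 is expected to give 260 nM, between 120 nM and 560 nM.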

Compound 3, half-maximal inhibitory concentration: 246 nM
For compound 3 the middle estimate is 1.1-fold (0.02 log units) above the measured one, and the stated range covers the measured number.
By their numbers in this assay, from the lowest: compounds 1, 3 and 2 (each within the scatter of the next, the first and the last beyond it).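

In this assay, hydrogen in place of ethoxycarbonyl gives a 1.6-fold lower number from compound 2 to compound 3 (0.20 log units; within the scatter), and hydrogen in place of trifluoromethyl gives a 1.3-fold higher number from compound 1 to compound 3 (0.12 log units; within the scatter). Compound 3, with neither group, thus shows that neither replacement moves the number beyond the scatter, though compound 1 and compound 2 alone stood apart. No other evidence bears on these steps. From the compounds shown here alone, whether an amine or a carboxylic acid on the same aromatic ring would give a step beyond the scatter remains open.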